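A few compounds are considered here, and "the series" means these few. Any claim that something is new, unique, unknown or untested is made for them only; others in the source may bear on it.

Series notes, urea set on the shared core. Compound 1 `O=C(Nc1ccc(Cl)cc1)Nc1cccc(CNc2nccnc2Cl)c1` gives 5470 nM in a functional assay on T-24 cells (Homo sapiens) for antiproliferative activity, read by MTT assay, with a stated time of 48 h (on this read-out lower numbers stand for stronger inhibition and higher numbers for weaker inhibition), which is the lowest of the three numbers in hand. Compound 2 `Cc1ccccc1NC(=O)Nc1cccc(CNc2nccnc2Cl)c1` gives 13600 nM in this assay, and compound 3 `Cc1ccc(NC(=O)Nc2cccc(CNc3nccnc3Cl)c2)cc1C` gives 8930 nM. Within the data shown here, the change a 2.5-fold higher number from compound 1 to compound 2 (0.40 log units; beyond the scatter) is the only step among the measured pairs that reaches beyond the scatter; a 1.6-fold higher number from compound 1 to compound 3 (0.21 log units; within the scatter) and a 1.5-fold lower number from compound 2 to compound 3 (0.18 log units; within the scatter) both stay within it.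

Compound 4 `O=C(Nc1cccc(CNc2nccnc2Cl)c1)NC1CCCCC1` has not yet been run in this assay. Compared with compound 1 the difference is cyclohexyl in place of 4-chlorophenyl on an amide-type nitrogen. The measured steps all bear on the same amide-type nitrogen, so they are the relevant comparison, but every one of them exchanges one aryl group for another aryl group; none introduces a non-aromatic ring, so their sizes only hint at how much this position tolerates. What they show is that moving away from 4-chlorophenyl has so far given a higher number, by a modest amount at most.

On that basis compound 4 is expected to give 9000 nM in this assay, in the range 3500 nM to 25000 nM. The step this estimate implies is a 1.6-fold higher number from compound 1 to compound 4 (0.22 log units; within the scatter), a modest rise that is expected to sit near the edge of the scatter rather than clearly beyond it.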

Compound 4, half-maximal inhibitory concentration: > 40000 nM
Compound 4: only a limit was reported; the forecaster's own chance of this, stated with the estimate: 10%; middle value at least 4.4-fold (0.64 log units) away from the limit.
By their numbers in this assay, from the lowest: compounds 1, 3 and 2 (each within the scatter of the next, the first and the last beyond it). At a limit, above all of these: compound 4.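

Changing the aryl group on the amide-type nitrogen to cyclohexyl produces an at least 7.3-fold higher number from compound 1 to compound 4 (0.86 log units; beyond the scatter) and an at least 4.4-fold higher number from compound 3 to compound 4 (0.65 log units; beyond the scatter) and an at least 2.9-fold higher number from compound 2 to compound 4 (0.46 log units; beyond the scatter) in the series. Among these compounds, the aryl-for-aryl exchanges among compounds 1, 2 and 3 gave no sign of this, so the non-aromatic ring of compound 4 is the first change at this position to lie beyond the scatter against all three aryl ureas, and the position is less tolerant than those exchanges alone suggested. Each of these steps is open-ended, since compound 4 carries a limit of the assay and not a number: the limit of > 40000 nM in this assay, at which 1 of the 4 values shown sits.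

The true size of the loss therefore remains undefined, and these compounds do not separate the loss of the aromatic ring from other differences between cyclohexyl and the aryl groups. On these data alone, it also remains open whether activity at this nitrogen could be recovered by a smaller cyclopentyl ring, a straight hexyl chain or a cyclohexyl ring carrying an amine, or whether a benzyl group would read closer to the aryl ureas.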